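Swapping the Small Ring Back to a Pyridine

A few compounds are considered here, and "the series" means these few. Any claim that something is new, unique, unknown or untested is made for them only; others in the source may bear on it.

The compounds share one core and differ only in the group on a saturated chain carbon bound to an oxygen on an aromatic ring and a saturated chain carbon. Compound 3 `C[C@@H](Oc1cc2oc(=O)n(CCC(=O)O)c2cc1Cl)c1ncco1` carries a 1,3-oxazol-2-yl group there, and in an assay on HEK293 cells for inhibition of kynurenine 3-monooxygenase (Homo sapiens), read by LC-MS, with a stated time of 20 h (a lower number here means a stronger inhibitor, a higher number a weaker inhibitor), compound 3 gives 7940 nM, the highest number of the three measured compounds and so the weakest inhibitor. Compound 1 `C[C@@H](Oc1cc2oc(=O)n(CCC(=O)O)c2cc1Cl)c1ccc(F)cn1` carries a 5-fluoropyridin-2-yl group, and in this assay compound 1 gives 25.1 nM. Compound 2 `CCOc1cc2oc(=O)n(CCC(=O)O)c2cc1Cl` carries only hydrogen, and in this assay compound 2 gives 398 nM. The steps of a 320-fold higher number from compound 1 to compound 3 (2.50 log units; beyond the scatter) and a 20-fold higher number from compound 2 to compound 3 (1.30 log units; beyond the scatter) show the oxazole group to be the worst of the three, while a 16-fold higher number from compound 1 to compound 2 (1.20 log units; beyond the scatter) shows the fluoropyridine group to bring a large gain over bare hydrogen.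

Compound 4 `Cc1cccc([C@@H](C)Oc2cc3oc(=O)n(CCC(=O)O)c3cc2Cl)n1` is the next step: 6-methylpyridin-2-yl in place of 1,3-oxazol-2-yl on a saturated chain carbon bound to an oxygen on an aromatic ring and a saturated chain carbon. The measured step most alike is a 320-fold higher number from compound 1 to compound 3 (2.50 log units; beyond the scatter) read in reverse, since compound 4 again carries a six-membered pyridine ring on that carbon, now with a methyl group rather than a fluorine. The step of a 20-fold higher number from compound 2 to compound 3 (1.30 log units; beyond the scatter) adds that the oxazole group is also worse than hydrogen, so a large drop in number is expected. The expected step is a 200-fold lower number from compound 3 to compound 4 (2.30 log units; beyond the scatter). Compound 4 is estimated at 40 nM, within 10 nM to 200 nM.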

Compound 4, half-maximal inhibitory concentration: 316 nM
Compound 4: the middle estimate sits 7.9-fold (0.90 log units) below what was measured; the whole stated range lies below it.
By their numbers in this assay, from the lowest: compound 1; then compounds 4 and 2 (each within the scatter of the next); then compound 3.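

Compound 4 shows that much of the loss seen with the 1,3-oxazol-2-yl group disappears when a 6-methylpyridin-2-yl group takes its place on this saturated chain carbon, a change worth a 25-fold lower number from compound 3 to compound 4 (1.40 log units; beyond the scatter) in this assay. A pyridine ring alone does not secure a strong inhibitor, however: the change from the 5-fluoropyridin-2-yl group gives a 13-fold higher number from compound 1 to compound 4 (1.10 log units; beyond the scatter), and replacing the hydrogen with 6-methylpyridin-2-yl gives only a 1.3-fold lower number from compound 2 to compound 4 (0.10 log units; within the scatter), so this larger group offers no readable gain over hydrogen. Nothing measured here explains why these groups differ so widely.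

The names 5-fluoropyridin-2-yl and 6-methylpyridin-2-yl show that compound 1 and compound 4 differ both in what is attached to the pyridine ring, fluorine or methyl, and in where it is attached, so these compounds cannot say which of the two matters more. Going by these compounds, a pyridin-2-yl group carrying neither fluorine nor methyl, or a plain phenyl ring, at this position would be a useful comparison, and its effect remains open here.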